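This account rests on a few compounds, and the source may have more. Where it says the series, first, only, none or still open, it means among the compounds named here.

Compound 1, `CCCCCNC(=O)NS(=O)(=O)c1cc(C#N)ccc1Oc1ccccc1C`: 1780 nM
Compound 2, `CCCCCNC(=O)NS(=O)(=O)c1cc(C#N)ccc1Oc1cccc(C)c1`: 680 nM
Compound 3, `Cc1ccc(Oc2ccc(C#N)cc2S(=O)(=O)NC(=O)NC(C)(C)C)cc1`: 680 nM

These three compounds were tested in a functional assay on HEK293 cells for antagonist activity at thromboxane A2 receptor (Homo sapiens), read by fluorescence and calcium flux; a higher number here means a weaker inhibitor, a lower number a stronger inhibitor. Going by the values given here, compound 3 stands level with compound 2 at the digits given, and the two together sit at the lowest numbers of the three; its only separation is from compound 1, whose number is higher than that of compound 3 by a margin beyond the scatter. Among the compounds with values here, the one measured step between neighbours, a 2.6-fold lower number from compound 1 to compound 2 (0.42 log units; beyond the scatter), comes from moving the methyl group on the phenoxy ring and says nothing about the urea end of the molecule.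

Compound 4, `CCCCCNC(=O)NS(=O)(=O)c1cc(C#N)ccc1Oc1ccc(C)cc1`, differs from compound 3 by pentyl in place of tert-butyl on an amide-type nitrogen. Within the data shown here, no measured pair isolates this exchange, so there is no direct precedent for its size. What can be said is that compound 2 carries the pentyl chain and compound 3 the tert-butyl group, and their values are indistinguishable, though they also differ at the phenoxy ring. Compound 4 combines the pentyl chain of compound 2 with the phenoxy substitution of compound 3, so the expectation is for no step beyond the scatter: compound 4 is estimated to come out as a 1.0-fold higher number from compound 3 to compound 4 (0.01 log units; within the scatter). The estimate for compound 4 in this assay is 700 nM, within the range 300 nM to 1600 nM.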

Compound 4, half-maximal inhibitory concentration: 630 nM
Compound 4: middle estimate off by 1.1-fold (0.05 log units), on the high side, and the stated range covers the measured number.
By their numbers in this assay, from the lowest: compounds 4, 2 and 3 (each within the scatter of the next); then compound 1.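

In this assay, the exchange of tert-butyl for pentyl on the amide-type nitrogen can now be read on its own: it gives a 1.1-fold lower number from compound 3 to compound 4 (0.03 log units; within the scatter), so with 4-methylphenyl on the oxygen, these two groups cannot be told apart. With the pentyl chain held fixed, 4-methylphenyl in place of 3-methylphenyl gives a 1.1-fold lower number from compound 2 to compound 4 (0.03 log units; within the scatter), while 4-methylphenyl in place of 2-methylphenyl gives a 2.8-fold lower number from compound 1 to compound 4 (0.45 log units; beyond the scatter), which shows that among these three pentyl compounds only the 2-methylphenyl compound stands apart. Nothing available here accounts for either result.

From the compounds shown here alone, the match between tert-butyl and pentyl rests on a single pair, so it remains open whether it would hold with 2-methylphenyl or 3-methylphenyl on the oxygen. Going by these compounds, it is also open how a short ethyl chain, a longer octyl chain or a cyclohexyl ring would compare on the same nitrogen, and whether a chain ending in an amine or a carboxylic acid would fit the same picture.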